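Second chloro on the 3-chlorophenyl of compound 3

The source may hold more compounds than are shown below. What is called first, only, known or untested is meant among the compounds shown, and "the series" means these compounds.

Measured in an assay on cells for agonist activity at ecdysone receptor (Bombyx mori), read by a luciferase reporter, with a stated time of 24 h; a lower number here means that less compound is needed, a higher number that more compound is needed for the effect:
compound 1 `CCc1ccccc1C(=O)N(NC(=O)c1ccccc1)C(C)(C)C` gives 589 nM
compound 2 `COc1ccccc1C(=O)N(NC(=O)c1ccccc1)C(C)(C)C` gives 525 nM
compound 3 `CC(C)(C)N(NC(=O)c1cccc(Cl)c1)C(=O)c1ccccc1Cl` gives 155 nM

Compound 3 gives the lowest number of the three in this assay; compound 2 sits a 1.1-fold lower number from compound 1 to compound 2 (0.05 log units; within the scatter) from compound 1, a gap within the scatter, while both stand clearly above compound 3. Going by the values given here, the only measured step, methoxy in place of ethyl on an aromatic carbon, does not touch the part of the molecule changed here.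

Compound 4 `CC(C)(C)N(NC(=O)c1cccc(Cl)c1Cl)C(=O)c1ccccc1Cl` differs from compound 3 in one place: chloro in place of hydrogen on an aromatic carbon. Among the compounds with values here, no measured pair in the set shows the effect of an added chloro, so there is no step to lean on. The change is a single heavy atom entering ortho to a chloro group and ortho to a large group, and its direction on the reporter read-out cannot be read from the data shown. The expectation is therefore a modest step, a 1.6-fold higher number from compound 3 to compound 4 (0.21 log units; within the scatter), with a wide range in either direction. Compound 4 is estimated at 250 nM in this assay, expected between 80 nM and 800 nM.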

Compound 4, half-maximal effective concentration: 9.33 nM
Compound 4: the middle estimate sits 27-fold (1.43 log units) above what was measured; the whole stated range lies above it.
By their numbers in this assay, from the lowest: compound 4; then compound 3; then compounds 2 and 1 (each within the scatter of the next).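

In this assay the change from 3-chlorophenyl to 2,3-dichlorophenyl is a 17-fold lower number from compound 3 to compound 4 (1.22 log units; beyond the scatter), so this aromatic carbon, ortho to a chloro group and ortho to a large group, is a place where one added chloro moves the number far beyond the scatter. Going by these compounds alone, the only earlier step, a 1.1-fold lower number from compound 1 to compound 2 (0.05 log units; within the scatter), lies within the scatter and falls in another part of the molecule, so it gave no sign that a single-atom change could matter this much anywhere. The entering chloro adds one heavy atom, with no ring, no hydrogen-bond donors or acceptors and no net charge, and no measurement in hand accounts for the size of this step.

From the compounds shown here alone, whether the lower number belongs to chloro itself or would also follow from fluoro, bromo, methyl or an amine on this carbon remains open. Also open, going by these compounds, is whether the effect depends on the chloro already present on this ring in compound 3, or would appear with hydrogen in its place.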